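A few compounds are considered here, and "the series" means these few. Any claim that something is new, unique, unknown or untested is made for them only; others in the source may bear on it.

Measured compounds:
compound 1 `COc1ccc2nc(Cl)c(/C=C3\SC(=S)NC3=O)cc2c1`: > 100 ug/mL
compound 2 `Cc1cccc2cc(/C=C3\SC(=S)NC3=O)c(Cl)nc12`: > 100 ug/mL

Of the compounds shown here, two have been tested in a toxicity assay on PANC-1 cells (Homo sapiens) for cytotoxicity, read by MTT assay, with a stated time of 48 h; a lower number here means a stronger inhibitor of growth, a higher number a weaker inhibitor of growth. For compound 1 the reading is only a limit, > 100 ug/mL, not a number. For compound 2 the reading is likewise a limit, > 100 ug/mL. Compound 1 therefore stands nowhere on a scale of numbers: it sits at the same limit as compound 2, and the limit of > 100 ug/mL in this assay, at which 2 of the 2 values shown sit, is all the measured set offers. Nothing in these two readings separates the compounds from each other.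

Compound 3 `O=C1NC(=S)S/C1=C\c1cc2cc(F)ccc2nc1Cl` has not yet been measured. It differs from compound 1 in one place: fluoro in place of methoxy on an aromatic carbon. Among the compounds with values here, with no measured step to lean on, the move from compound 1 to compound 3 is expected to be none beyond the usual scatter, and the estimated a number no higher from compound 1 to compound 3 (the limit leaves the size open) says as much. Compound 3 is expected to give about 100 ug/mL in this assay, within 50 ug/mL to 200 ug/mL, and most probably the assay will again report only a limit.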

Compound 3, concentration for 50% growth inhibition: > 100 ug/mL
Compound 3 gave a limit, no number; the forecaster's own chance of this, stated with the estimate: 75%; the middle value sits exactly at the limit.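

Compound 1 and compound 3 each gave only a limit in this assay, so the step between them cannot be read. What stays open is how strongly compound 1, compound 2 and compound 3 inhibit growth, and whether they differ at all: the limit of > 100 ug/mL in this assay, at which 3 of the 3 values shown sit.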